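Changing Only Configuration: From Compound 2 to Compound 3

A few compounds are considered here, and "the series" means these few. Any claim that something is new, unique, unknown or untested is made for them only; others in the source may bear on it.

Measured so far:
Compound 1, `CC(C)(CO)[C@H](O)C(=O)N/C=C/C(=O)OCc1ccccc1`: 19%
Compound 2, `CCOC(=O)/C=C\NC(=O)[C@H](O)C(C)(C)CO`: 1%

Within the data shown here, in an ADME assay on WI-38 cells (Homo sapiens) for inhibition, read by CellTiter-Glo, with a stated time of 48 h, tested at 100 uM (a higher number here means more inhibition at the concentration tested (going by the name of the read-out), a lower number less inhibition), compound 2 gives 1%, the lowest of the two numbers; the only other value, that of compound 1, lies higher by more than the usual scatter. Compound 3, `CCOC(=O)/C=C/NC(=O)[C@@H](O)C(C)(C)CO`, keeps every atom and bond of compound 2: the two compounds have the same atoms and bonds and differ only in configuration as drawn: 2 of 2 stereo elements differ; a stereocentre at a saturated chain carbon is drawn R in compound 2 and S in compound 3; a double bond is drawn Z in compound 2 and E in compound 3. Nothing measured here isolates such a configuration change, so a modest rise that may stay within the scatter is what the step of a number 7 percentage points higher from compound 2 to compound 3 (within the scatter) is expected to be. Compound 3 is therefore estimated at 8%, with a range from 0% to 25%.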

Compound 3, a percentage reported as inhibition, at one concentration (the size of the read-out at that concentration, not a potency): -6%
Compound 3: the middle estimate sits 14 percentage points above what was measured, and the stated range ends above it.
By their numbers in this assay, from the lowest: compounds 3 and 2 (each within the scatter of the next); then compound 1.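

Among these compounds, changing both stereo elements together gives a number 7 percentage points lower from compound 2 to compound 3 (within the scatter) in this assay, so configuration as drawn, the one thing separating this pair, moves the read-out by no more than the scatter: the fact that compounds 2 and 3 differ only in the configuration as drawn. Methyl in place of phenyl on a saturated chain carbon bound to an oxygen next to a carbonyl group gives a number 25 percentage points lower from compound 1 to compound 3 (beyond the scatter), the first listed step that clears the scatter.

The stereocentre and the double bond change together here, so neither can be judged alone. Going by these compounds, how an amine or a longer chain would read at the methyl position remains open.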